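The source may hold more compounds than are shown below. What is called first, only, known or untested is meant among the compounds shown, and "the series" means these compounds.

In a functional assay on HCT-15 cells (Homo sapiens) for antiproliferative activity, read by MTT assay, with a stated time of 72 h (a lower number here means a stronger inhibitor, a higher number a weaker inhibitor), compound 1 `CCCCn1ccnc1-c1cc(OC)c(OC)c(OC)c1` gives > 100000 nM, which is a limit of the assay and not a number. Going by the values given here, compound 1 therefore offers no exact starting point, and the only measured number comes from compound 2 `COc1cc(-c2nccn2-c2ccc3cc[nH]c3c2)cc(OC)c1OC`, which gives 4000 nM in this assay. Compound 3 `COc1cc(-c2nccn2-c2ccc(C)cc2)cc(OC)c1OC` keeps the core of compound 1 but carries 4-methylphenyl in place of butyl on an aromatic nitrogen, next to the ring atom that bears a large group. The change brings in one six-membered aromatic ring of carbon only. In this assay, stronger inhibition is expected, with an estimated step of an at least 6.6-fold lower number from compound 1 to compound 3 (0.82 log units; beyond the scatter). This expectation rests on compound 2, which gives 4000 nM. For compound 3, the half-maximal inhibitory concentration is estimated at 15000 nM, with an expected range from 3000 nM to 80000 nM.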

Compound 3, half-maximal inhibitory concentration: 800 nM
For compound 3 the middle estimate is 19-fold (1.27 log units) above the measured one; the measured number lies below the stated range.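

In this assay, 4-methylphenyl in place of butyl on this aromatic nitrogen gives an at least 120-fold lower number from compound 1 to compound 3 (2.09 log units; beyond the scatter) and so brings a measured number where the butyl compound had none. The value of compound 1 at > 100000 nM is a limit of the assay and not a number. The step can therefore be read only as a lower bound on the change, because it starts from that limit: the limit of > 100000 nM in this assay, at which 1 of the 3 values shown sits.

The compounds shown do not separate the effect of the six-membered aromatic ring from that of its methyl, so a plain phenyl at this nitrogen would be the direct test. They also leave open how a benzyl group, a longer chain or a ring bearing an amine or a carboxylic acid would fare at this place.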